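Swapping a meta amide for methyl on a benzohydroxamate

The source may hold more compounds than are shown below. What is called first, only, known or untested is meant among the compounds shown, and "the series" means these compounds.

Measured compounds: compound 1 `O=C(NO)c1cccc(C(=O)NCc2ccccc2)c1`, 210 nM; compound 2 `CNC(=O)c1cccc(C(=O)NO)c1`, 14000 nM.

Compound 1 and compound 2 share a benzohydroxamate core. In an assay on isolated protein for inhibition of histone deacetylase 8 (Homo sapiens), read by fluorescence, with a stated time of 60 min (a lower number here means a stronger inhibitor, a higher number a weaker inhibitor), compound 1 gives 210 nM, while compound 2 gives 14000 nM, the highest of the two numbers shown; the step of a 67-fold higher number from compound 1 to compound 2 (1.82 log units; beyond the scatter) is large and beyond the scatter. Compound 3 `Cc1cccc(C(=O)NO)c1` differs from compound 2 by methyl in place of methylcarbamoyl on an aromatic carbon. For the measured compounds named here, no measured step carries this change; the only step available, a 67-fold higher number from compound 1 to compound 2 (1.82 log units; beyond the scatter), shows that removing a phenyl group from this arm of the molecule greatly weakened inhibition, and compound 3 now loses the amide arm entirely. Compound 3 is therefore expected to remain a weak inhibitor, with a step of a 1.4-fold higher number from compound 2 to compound 3 (0.15 log units; within the scatter) estimated relative to compound 2. In this assay compound 3 is estimated at 20000 nM, within a range of 5000 nM to 80000 nM.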

Compound 3, half-maximal inhibitory concentration: 3300 nM
Estimate against measurement, compound 3: 6.1-fold (0.78 log units) above; the measured number lies below the stated range.
By their numbers in this assay, from the lowest: compound 1; then compound 3; then compound 2.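

In this assay the change gives a 4.2-fold lower number from compound 2 to compound 3 (0.63 log units; beyond the scatter) and this modest step lies beyond the scatter, so on this aromatic carbon a plain methyl gives a lower number than the methylcarbamoyl group. The earlier step, a 67-fold higher number from compound 1 to compound 2 (1.82 log units; beyond the scatter) as the phenyl was lost, showed only how much the end of the amide arm counted; the new step shows that the amide left behind without that phenyl brings no gain over methyl. No measurement shown here accounts for the lower number of compound 3.

The compounds shown leave open how an amine, a carboxylic acid or a bare hydrogen on this carbon would compare with methyl. They also leave open whether a longer carbon chain ending in phenyl, with no amide in it, would reach the low number of compound 1.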